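Swapping Furan Isomers on a Shared Core

A few compounds are considered here, and "the series" means these few. Any claim that something is new, unique, unknown or untested is made for them only; others in the source may bear on it.

The study covers four compounds that pair off onto two cores. Compound 3 `Cc1nc(N)c2c(-c3ccoc3)cn([C@@H]3O[C@H](CO)[C@@H](O)[C@H]3O)c2n1` and compound 1 `Cc1nc(N)c2c(-c3ccco3)cn([C@@H]3O[C@H](CO)[C@@H](O)[C@H]3O)c2n1` share one core, while compound 2 `COc1nc(N)nc2c1c(-c1ccoc1)cn2[C@@H]1O[C@H](CO)[C@@H](O)[C@H]1O` and the unmeasured compound 4 `COc1nc(N)nc2c1c(-c1ccco1)cn2[C@@H]1O[C@H](CO)[C@@H](O)[C@H]1O` share another; how the two cores differ is not broken down here.

In a functional assay on A549 cells (Homo sapiens), read by MTT assay, with a stated time of 72 h (a higher number here means a weaker inhibitor, a lower number a stronger inhibitor), compound 3 gives > 20000 nM, which is a limit of the assay rather than a number. Compound 1 in this assay likewise gives a limit, > 20000 nM. Compound 2 in this assay also gives only a limit, > 20000 nM. Because (the limit of > 20000 nM in this assay, at which 3 of the 3 values shown sit), the step that the two limits leave unreadable from compound 3 to compound 1 cannot be read. The change behind that step is furan-2-yl in place of furan-3-yl on an aromatic carbon.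

The same change is made from compound 2 to compound 4: furan-2-yl in place of furan-3-yl on an aromatic carbon. The place described is the same word for word in both cases, so this is the same change made on a second core. Since no measured step gives a size for it, nothing shown points to a gain in this assay.

Compound 4 is expected to sit at 30000 nM, most likely again reported only as a limit. The step that the limit leaves unreadable from compound 2 to compound 4 is expected to be essentially flat. This expectation rests on compound 1, which after the same change gives > 20000 nM, a limit, and on compound 2, whose > 20000 nM is a limit as well.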

Compound 4, half-maximal inhibitory concentration: > 20000 nM
Compound 4: a limit, no number (the forecaster's own chance of this, stated with the estimate: 90%); the middle value does not contradict the limit.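

No new step can be read from compound 2 to compound 4, so the change from furan-3-yl to furan-2-yl has no readable size on this core in this assay. Neither compound gives a number, and the step stays unreadable for this reason: the limit of > 20000 nM in this assay, at which 4 of the 4 values shown sit.

The compounds shown leave open whether furan-2-yl and furan-3-yl differ at all in this assay on either core, and how strong any of the four compounds is.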